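The source may report more compounds than this note shows. Statements on the series, on what has been measured and on what is new or still open speak of the compounds shown alone.

Measured so far:
- Compound 1, `O=c1nc2oc(CCCCCCCCCOCC3CCCC3)cc2cn1[C@H]1C[C@H](O)[C@@H](CO)O1`. In a functional assay on HEL cells (Homo sapiens) (on this read-out lower numbers stand for higher toxicity in this test and higher numbers for lower toxicity in this test), compound 1 gives > 200000 nM, which is a limit of the assay.
- Compound 2, `CCCCOCCCCCCCCCc1cc2cn([C@H]3C[C@H](O)[C@@H](CO)O3)c(=O)nc2o1`. In this assay compound 2 gives > 200000 nM, again a limit of the assay.

Compound 2 therefore stands at the limit of this assay rather than at a number; (the limit of > 200000 nM in this assay, at which 2 of the 2 values shown sit). Among the measured compounds shown here, the one measured step, a step that the two limits leave unreadable from compound 1 to compound 2, is unreadable in size, so nothing quantitative is known about how the chain end affects this read-out.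

Compound 3, `CCCCCOCCCCCCCCCc1cc2cn([C@H]3C[C@H](O)[C@@H](CO)O3)c(=O)nc2o1`, differs from compound 2 by methyl in place of hydrogen on a saturated chain carbon, four bonds along the chain from an oxygen on a saturated carbon. For the measured compounds named here, no measured step with a readable size bears on this change; the only comparable step, from compound 1 to compound 2, sits between two limits. The expectation for compound 3 in this assay is therefore no step beyond the scatter, a number no higher from compound 2 to compound 3 (the limit leaves the size open), with compound 3 estimated at 200000 nM, range 100000 nM to 400000 nM, most likely again reported as a limit.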

Compound 3, half-maximal cytotoxic concentration: > 200000 nM
Compound 3: a limit, no number (the forecaster's own chance of this, stated with the estimate: 85%); the middle value lies on the limit itself.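

In this assay, among the compounds shown here, compound 3 gives > 200000 nM, a limit of the assay, so no step from compound 1 or compound 2 to compound 3 can be read: the limit of > 200000 nM in this assay, at which 3 of the 3 values shown sit.

The compounds shown leave open whether the chain end changes this read-out at all.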